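The compounds below may be only part of what the source reports. "The series", "measured", "known", "first", "only" and "open" are said of these compounds alone.

Compound 1 `CCOC(=O)c1c(-c2cccc(OC)c2)[nH]c2cc(OC)ccc2c1=O` and compound 2 `CCOC(=O)c1c(-c2cccc(F)c2)[nH]c2cc(OC)ccc2c1=O` share one core. In an ADME assay on HEK293 cells (Homo sapiens) for cytotoxicity, read by luminescence, with a stated time of 72 h (on this read-out higher numbers stand for an effect only at larger amounts of compound and lower numbers for an effect already at smaller amounts), compound 1 gives > 22000 nM, a limit of the measurement rather than a number. In this assay compound 2 likewise gives > 22000 nM, again only a limit. The step that the two limits leave unreadable from compound 1 to compound 2 therefore cannot be sized, since the limit of > 22000 nM in this assay, at which 2 of the 2 values shown sit, holds both values. Compound 3 `CCOC(=O)c1c(-c2cccc(CO)c2)[nH]c2cc(OC)ccc2c1=O` differs from compound 2 by hydroxymethyl in place of fluoro on an aromatic carbon. Among the measured compounds shown here, no measured step shows how that change acts here, so the expected step is taken as a step that the limit leaves unreadable from compound 2 to compound 3, small and of no readable direction. Compound 3 is estimated at 30000 nM, within 15000 nM to 90000 nM.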

Compound 3, half-maximal effective concentration: > 22000 nM
Compound 3: a limit, no number; the forecaster's own chance of this, stated with the estimate: 85%; the middle value lies beyond the limit too.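

Among the compounds shown here, compound 3 gives only a limit, as do compound 1 and compound 2, so no step among the three can be read: the limit of > 22000 nM in this assay, at which 3 of the 3 values shown sit. Left open is whether the methoxy, fluoro and hydroxymethyl groups differ at all in this assay, and at what amount any of these compounds acts.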